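Replacing phenoxy with tert-butyl in a growth-inhibiting series

This account rests on a few compounds, and the source may have more. Where it says the series, first, only, none or still open, it means among the compounds named here.

- compound 1 `O=C(CCl)NC(=O)Nc1ccc(C2CCCCC2)cc1`: 900 nM
- compound 2 `O=C(CCl)NC(=O)Nc1ccc(-c2ccccc2)cc1`: 1400 nM
- compound 3 `O=C(CCl)NC(=O)Nc1ccc(Oc2ccccc2)cc1`: 4200 nM

In a functional assay on M21 cells (Homo sapiens) for inhibition, read by sulforhodamine B assay, with a stated time of 48 h (a higher number here means a weaker inhibitor of growth, a lower number a stronger inhibitor of growth), compound 3 is the weakest of the three at 4200 nM. Compound 4 `CC(C)(C)c1ccc(NC(=O)NC(=O)CCl)cc1`, not yet measured, has tert-butyl in place of phenoxy on an aromatic carbon. Within the data shown here, no measured compound carries tert-butyl, so only neighbouring steps bear on this change. Those leading to phenoxy are a 4.7-fold higher number from compound 1 to compound 3 (0.67 log units; beyond the scatter) and a 3.0-fold higher number from compound 2 to compound 3 (0.48 log units; beyond the scatter), whereas a 1.6-fold higher number from compound 1 to compound 2 (0.19 log units; within the scatter) shows that cyclohexyl and phenyl do not separate. If tert-butyl follows cyclohexyl and phenyl, the expected change is a 2.8-fold lower number from compound 3 to compound 4 (0.45 log units; beyond the scatter), towards a lower number. For compound 4 the estimated value is 1500 nM, with an expected range of 700 nM to 3500 nM.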

Compound 4, concentration for 50% growth inhibition: 1100 nM
Beside the measured number, compound 4's estimate is 1.4-fold (0.13 log units) above it; low and high end bracket the measured number.
By their numbers in this assay, from the lowest: compounds 1, 4 and 2 (each within the scatter of the next); then compound 3.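

In this assay the change gives a 3.8-fold lower number from compound 3 to compound 4 (0.58 log units; beyond the scatter), yet a 1.3-fold lower number from compound 2 to compound 4 (0.10 log units; within the scatter) and a 1.2-fold higher number from compound 1 to compound 4 (0.09 log units; within the scatter), so tert-butyl does not separate from phenyl or cyclohexyl. At this position a group without a ring therefore sits with the two groups that carry one, and among these four compounds only phenoxy stands apart. Nothing offered here accounts for the result. What the compounds shown leave open is whether a smaller group such as methyl, or an amine or a carboxylic acid at this place, would stay with compound 1, compound 2 and compound 4 or move away from them.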